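Trifluoromethyl for ethoxy on the pyridine arm

The source may hold more compounds than are shown below. What is called first, only, known or untested is meant among the compounds shown, and "the series" means these compounds.

Measured compounds:
compound 1 `Cc1nc(C)n(CC(=O)N2CCN(c3sc(C(F)(F)F)nc3-c3cnc(OC4CCC4)nc3)C[C@H]2C)n1`, 78 nM
compound 2 `CCOc1ccc(-c2nc(C(F)(F)F)sc2N2CCN(C(=O)Cn3nc(C)nc3C)[C@H](C)C2)cn1`, 505 nM

Within the data shown here, in a functional assay on U2OS cells for antagonist activity at C-X-C chemokine receptor type 3 (Homo sapiens), read by beta-arrestin recruitment (on this read-out lower numbers stand for stronger inhibition and higher numbers for weaker inhibition), compound 2 stands at the high end of the two numbers so far; its nearest neighbour is compound 1, and the step of a 6.5-fold higher number from compound 1 to compound 2 (0.81 log units; beyond the scatter) takes the number up by a modest amount when 6-ethoxypyridin-3-yl replaces 2-(cyclobutyloxy)pyrimidin-5-yl.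

Compound 3 `Cc1nc(C)n(CC(=O)N2CCN(c3sc(C(F)(F)F)nc3-c3ccc(C(F)(F)F)nc3)C[C@H]2C)n1` is not yet measured. It differs from compound 2 by trifluoromethyl in place of ethoxy on an aromatic carbon, so that the arm reads 6-(trifluoromethyl)pyridin-3-yl instead of 6-ethoxypyridin-3-yl.

Among the measured compounds shown here, no measured step covers this exchange; the one step known, from compound 1 to compound 2, changed both ring and ether and says only that the ethoxy-bearing arm sits weaker than the cyclobutyloxy one. Trifluoromethyl has been neither tried nor compared here. The expectation for compound 3 is therefore a somewhat higher number in this assay, with wide uncertainty, an expected step of a 2.0-fold higher number from compound 2 to compound 3 (0.30 log units; within the scatter). Compound 3 is estimated at 1000 nM, expected to fall between 300 nM and 4000 nM.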

Compound 3, half-maximal inhibitory concentration: 608 nM
Estimate against measurement, compound 3: 1.6-fold (0.22 log units) above, within the range that was stated.
By their numbers in this assay, from the lowest: compound 1; then compounds 2 and 3 (each within the scatter of the next).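

In this assay, on an aromatic carbon next to the ring nitrogen and para to a large group, the exchange of ethoxy for trifluoromethyl gives a 1.2-fold higher number from compound 2 to compound 3 (0.08 log units; within the scatter) and so does not separate the two groups, although ethoxy carries a hydrogen-bond acceptor and trifluoromethyl none. The arm from compound 1 still differs from this second pyridine arm, with a 7.8-fold higher number from compound 1 to compound 3 (0.89 log units; beyond the scatter) and the 6-ethoxypyridin-3-yl arm of compound 2 also reading beyond the scatter from compound 1, so among these three compounds the only clear separation lies between the 2-(cyclobutyloxy)pyrimidin-5-yl arm and the two pyridine arms. No measurement available here offers a reason why ethoxy and trifluoromethyl read alike at this place.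

The compounds shown do not tell whether the gap to compound 1 belongs to the pyrimidine ring or to the cyclobutyloxy group, as each step to compound 1 changes the ring and the group on it together. They also leave open how this place would respond to an amine or a carboxylic acid, or to a longer ether chain on the pyridine.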